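A few compounds are considered here, and "the series" means these few. Any claim that something is new, unique, unknown or untested is made for them only; others in the source may bear on it.

Measured so far in a functional assay on HL-60 cells (Homo sapiens) for cytotoxicity, read by MTT assay, with a stated time of 72 h; on this read-out higher numbers stand for weaker inhibition and lower numbers for stronger inhibition:
Compound 1 `CC(=O)O[C@H](C/C(C)=C/CO)[C@@]1(C)[C@H](C)CC=C2[C@@H]1CCCC2(C)C`: > 30000 nM (a limit)
Compound 2 `CCC(=O)OC/C=C(\C)C[C@@H](O)[C@@]1(C)[C@H](C)CC=C2[C@@H]1CCCC2(C)C`: > 30000 nM (a limit)

Compound 2 has no exact number and stands only at its limit of > 30000 nM. Within the data shown here, the whole series so far sits at one value: the limit of > 30000 nM in this assay, at which 2 of the 2 values shown sit.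

Compound 3 `CCCC(=O)OC/C=C(\C)C[C@@H](O)[C@@]1(C)[C@H](C)CC=C2[C@@H]1CCCC2(C)C` differs from compound 2 by a single change in the ester, propanoyl to propylcarbonyl: methyl in place of hydrogen on a saturated chain carbon, two bonds along the chain from a carbonyl carbon. This places methyl in place of hydrogen on a saturated chain carbon, two bonds along the chain from a carbonyl carbon.

Among the measured compounds shown here, no measured step is available as a guide. In this assay, no step beyond the scatter is expected, and a report at the same limit is the likeliest outcome. The estimated change is a number no higher from compound 2 to compound 3 (the limit leaves the size open). The estimate for compound 3 is 30000 nM, with an expected range of 15000 nM to 45000 nM.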

Compound 3, half-maximal inhibitory concentration: > 30000 nM
Compound 3 was reported as a limit (the forecaster's own chance of this, stated with the estimate: 75%); the middle value lies on the limit itself.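

No step can be read from compound 2 to compound 3, as both are reported only as limits in this assay: the limit of > 30000 nM in this assay, at which 3 of the 3 values shown sit.

The compounds shown leave open whether any change to the ester or the shared core would give an exact number in this assay.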